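The compounds below may be only part of what the source reports. "The series", "measured", "known", "first", "only" and "open" are said of these compounds alone.

Within the data shown here, in a functional assay on SW-620 cells (Homo sapiens) for antiproliferative activity, read by MTT assay, with a stated time of 72 h (a lower number here means a stronger inhibitor, a higher number a weaker inhibitor), compound 1 `O=C1NC(O)(CCn2cnc3cc[nH]c3c2=O)C(OCc2ccccc2)=C1OCc1ccccc1` gives 90700 nM as the higher of the two numbers so far. Compound 2 `O=C1O/C(=C\Cn2cnc3cncc(Br)c32)C(OCc2ccccc2)=C1OCc1ccccc1` gives 32900 nM as the lower number, and the gap lies beyond the scatter. Compound 3 `O=C1NC(O)(CCn2cnc3cncc(Br)c32)C(OCc2ccccc2)=C1OCc1ccccc1` keeps the core of compound 1 and differs from it in one place, described as a group of 10 heavy atoms (6 carbon, 3 nitrogen, 1 bromine; one five-membered aromatic ring with 2 hetero atoms, one six-membered aromatic ring with 1 hetero atom) in place of a group of 10 heavy atoms (6 carbon, 3 nitrogen, 1 oxygen; one five-membered aromatic ring with 1 hetero atom, one six-membered aromatic ring with 2 hetero atoms), on a saturated chain carbon, two bonds along the chain from a saturated ring carbon on a saturated chain carbon, two bonds along the chain from a saturated ring carbon. Among the measured compounds shown here, no measured step isolates this change, so the data do not fix its size in this assay. The entering group also occurs in compound 2, which reads 32900 nM in that assay, so a modest downward step is expected, close to the edge of the scatter. The expected change is a 2.3-fold lower number from compound 1 to compound 3 (0.36 log units; beyond the scatter) as a central estimate. For compound 3 the estimated value is 40000 nM with an expected range from 15000 nM to 100000 nM in this series.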

Compound 3, half-maximal inhibitory concentration: > 100000 nM
Compound 3: only a limit was reported; the forecaster's own chance of this, stated with the estimate: 15%; middle value at least 2.5-fold (0.39 log units) from the limit.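

In this assay compound 3 reads > 100000 nM, which is a limit of the assay and not a number. On the saturated chain carbon, two bonds along the chain from a saturated ring carbon, exchanging the two groups of 10 heavy atoms gives an at least 1.1-fold higher number from compound 1 to compound 3 (0.04 log units; that floor lies within the scatter), so this change brings no lower number on the core of compound 1, even though the entering group also occurs in compound 2. Only a floor for the step can be read, not its size: the limit of > 100000 nM in this assay, at which 1 of the 3 values shown sits.

The step changes the ring hetero atoms and the bromine together, so the compounds shown do not separate the two. As far as these compounds go, whether a chlorine or an amine in place of the bromine, or a longer chain at this place, would bring a number inside the range of this assay stays open.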